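Swapping the aryl group on the chalcone carbonyl

A few compounds are considered here, and "the series" means these few. Any claim that something is new, unique, unknown or untested is made for them only; others in the source may bear on it.

Measured compounds:
compound 1 `COc1cc(-c2cc(/C=C/C(=O)c3ccc(N)cc3)[nH]n2)cc(OC)c1OC` gives 26%
compound 2 `COc1ccc(C(=O)/C=C/c2cc(-c3cc(OC)c(OC)c(OC)c3)n[nH]2)cc1` gives -29%

In a functional assay on TK-10 cells (Homo sapiens) for cytotoxicity, read by sulforhodamine B assay, with a stated time of 48 h, tested at 10 uM (a lower number here means a stronger effect, a higher number a weaker effect of the compound at the concentration tested), compound 1 stands highest of the two numbers measured, with compound 2 as its nearest neighbour. Among the measured compounds shown here, the one measured step, a number 55 percentage points lower from compound 1 to compound 2 (beyond the scatter), changes the same aryl group that is altered here. Compound 3 `COc1cc(-c2cc(/C=C/C(=O)c3ccc(F)c(F)c3)[nH]n2)cc(OC)c1OC` differs from compound 1 in one place: 3,4-difluorophenyl in place of 4-aminophenyl on a carbonyl carbon. For the measured compounds named here, since the only change at this place in the data gave a large fall, a fall beyond the scatter is expected for compound 3 too, though its size cannot be fixed from a single step. Compound 3 is therefore estimated at -8%, between -45% and 25%, a step of a number 34 percentage points lower from compound 1 to compound 3 (beyond the scatter).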

Compound 3, a percentage reported as activity, at one concentration (the size of the read-out at that concentration, not a potency): -13%
For compound 3 the middle estimate is 5 percentage points above the measured one; measured number inside the range.
By their numbers in this assay, from the lowest: compound 2; then compound 3; then compound 1.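

In this assay, 3,4-difluorophenyl in place of 4-aminophenyl on the carbonyl carbon gives a number 39 percentage points lower from compound 1 to compound 3 (beyond the scatter), so the fall seen with 4-methoxyphenyl is not confined to that one group. The two replacements do not read alike, however, with a number 16 percentage points higher from compound 2 to compound 3 (beyond the scatter), so the number at this position depends on which group replaces 4-aminophenyl. As far as these compounds go, whether a plain phenyl, a pyridine ring or a carboxylic acid on this carbonyl carbon would follow compound 2 or compound 3 remains open. No evidence on the cause of these differences is available here.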